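The compounds below may be only part of what the source reports. "The series", "measured", "known", "first", "only" and "open" are said of these compounds alone.

Measured compounds in this series:

- compound 1, `O=C(O)CC/C=C\CC1=CCC[C@@H]1NS(=O)(=O)c1ccc(F)cc1`: 1300 nM
- compound 2, `O=C(O)COCCCCC1=CCC[C@@H]1NS(=O)(=O)c1ccccc1[N+](=O)[O-]`: 1900 nM
- compound 3, `O=C(O)CCC/C=C\CC1=CCC[C@@H]1NS(=O)(=O)c1ccccc1[N+](=O)[O-]`: 680 nM

In a functional assay on a cell-free system (plasma) for inhibition of thromboxane A2 receptor (Homo sapiens), read by turbidimetry (on this read-out higher numbers stand for weaker inhibition and lower numbers for stronger inhibition), compound 2 gives the highest of the three numbers; compound 1 lies within the scatter of it, while compound 3 stands a 2.8-fold lower number from compound 2 to compound 3 (0.45 log units; beyond the scatter), a modest step that changes the acid-bearing chain and leaves the 2-nitrophenyl on the sulfonyl sulfur untouched.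

Compound 4, `O=C(O)COCCCCC1=CCC[C@@H]1NS(=O)(=O)c1ccc(F)cc1F`, keeps the chain of compound 2 and differs only at the sulfonyl aryl group: 2,4-difluorophenyl in place of 2-nitrophenyl on a sulfonyl sulfur

Going by the values given here, no measured step changes the aryl group on the sulfonyl sulfur alone. Compound 1 carries a fluorinated phenyl and compound 3 a 2-nitrophenyl, but they also differ in the chain. In this assay compound 1 gives 1300 nM and compound 3 gives 680 nM, and these two values cannot be read as the effect of the aryl change. With nothing bearing on this step, no change beyond the scatter is expected, and the number for compound 4 is estimated near that of compound 2, as no change at the digits printed from compound 2 to compound 4 (within the scatter). The estimate for compound 4 in this assay is 1900 nM, expected between 700 nM and 5000 nM.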

Compound 4, half-maximal inhibitory concentration: 1800 nM
Compound 4: middle estimate off by 1.1-fold (0.02 log units), on the high side, and the stated range covers the measured number.
By their numbers in this assay, from the lowest: compounds 3, 1, 4 and 2 (each within the scatter of the next, the first and the last beyond it).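

In this assay, with the chain of compound 2 held fixed, the exchange on the sulfonyl sulfur gives a 1.1-fold lower number from compound 2 to compound 4 (0.02 log units; within the scatter). Going by these compounds alone, this is the first reading of the aryl group alone, and it shows that on this chain 2,4-difluorophenyl, with 0 hydrogen-bond acceptors, can stand in place of 2-nitrophenyl, with 2, without a change beyond the scatter. Nothing at hand explains this result.

On these data alone, whether the same exchange holds on the 5-carboxypent-1-en-1-yl chain of compound 3 remains open, since that chain is paired here only with 2-nitrophenyl. Also open, as far as these compounds go, is how this position responds to groups of another kind, such as an aminophenyl, a carboxyphenyl or a naphthyl in place of the substituted phenyl.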